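The source may report more compounds than this note shows. Statements on the series, on what has been measured and on what is new or still open speak of the compounds shown alone.

In a functional assay on HUVEC cells (Homo sapiens) for antiproliferative activity, read by MTT assay, with a stated time of 48 h (a lower number here means a stronger inhibitor, a higher number a weaker inhibitor), compound 1 `Cc1cccc(/C=C/c2nnc(-c3ccc4c(c3)OCCO4)o2)c1` gives 40600 nM. Compound 2 `COc1cccc(/C=C/c2nnc(-c3ccc4c(c3)OCCO4)o2)c1` gives > 50000 nM, which is a limit of the assay and not a number. This is the limit of > 50000 nM in this assay, at which 1 of the 2 values shown sits, so compound 2 has no exact position on the scale. Compound 3 `COc1ccc(/C=C/c2nnc(-c3ccc4c(c3)OCCO4)o2)cc1` comes next, and the change is 4-methoxyphenyl in place of 3-methoxyphenyl on a double-bonded chain carbon bound to a double-bonded chain carbon. Within the data shown here, the only measured step is an at least 1.2-fold higher number from compound 1 to compound 2 (0.09 log units; that floor lies within the scatter). It replaces one group with another and does not move the methoxy, so it bears only loosely on this change. Among the measured compounds shown here, no measured step tests 4-methoxyphenyl against 3-methoxyphenyl. For the measured compounds named here, with compound 1 at 40600 nM as the only exact value, no step beyond the scatter is expected in this assay, and the expected change is a number no higher from compound 2 to compound 3 (the limit leaves the size open). The estimate for compound 3 is 50000 nM, with an expected range of 22000 nM to 100000 nM.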

Compound 3, half-maximal inhibitory concentration: > 50000 nM
Compound 3 gave a limit, no number; the forecaster's own chance of this, stated with the estimate: 55%; the middle value lies on the limit itself.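

In this assay compound 3 gives > 50000 nM, which is a limit of the assay and not a number. The step for 4-methoxyphenyl in place of 3-methoxyphenyl cannot be read, because both compounds of that pair stand at a limit: the limit of > 50000 nM in this assay, at which 2 of the 3 values shown sit. Replacing 3-methylphenyl with 4-methoxyphenyl gives an at least 1.2-fold higher number from compound 1 to compound 3 (0.09 log units; that floor lies within the scatter), so the 4-methoxyphenyl group, like the 3-methoxyphenyl group, yields no exact value and no step beyond the scatter.

From the compounds shown here alone, how far the true values of compound 2 and compound 3 lie past the limit remains open, and with it any real difference between the two methoxyphenyl groups. Also open, going by these compounds, is whether an amine or a carboxylic acid in place of the methoxy would bring an exact value within reach in this assay.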